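This account rests on a few compounds, and the source may have more. Where it says the series, first, only, none or still open, it means among the compounds named here.

Measured so far:
compound 1 `CNC(=O)c1cc(Oc2ccc(C3=NNC(c4cc(OC)c(OC)c(OC)c4)C3)cc2)ccn1` gives 37100 nM
compound 2 `CNC(=O)c1cc(Oc2ccc(C3=NNC(c4cccc([N+](=O)[O-])c4)C3)cc2)ccn1` gives "not determined" (no result reported)

Going by the values given here, in a functional assay on A549 cells (Homo sapiens) for cytotoxicity, read by MTT assay, with a stated time of 72 h (on this read-out higher numbers stand for weaker inhibition and lower numbers for stronger inhibition), compound 1 gives 37100 nM as the only number available. Compound 2 is recorded as "not determined" (no result reported) and so has no standing on the numbers. Compound 3 `CNC(=O)c1cc(Oc2ccc(C3=NNC(c4ccc(Br)cc4)C3)cc2)ccn1` is still unmeasured. The change 4-bromophenyl in place of 3-nitrophenyl on a saturated ring carbon puts 4-bromophenyl in place of 3-nitrophenyl on a saturated ring carbon. Among the compounds with values here, no measured step shows what such a swap does, so no step size or direction can be read from the data. Within the data shown here, the only guide is compound 1 at 37100 nM in the same assay, and a value in that region is expected, with no difference beyond the scatter. Compound 3 is estimated at 25000 nM with an expected range from 8000 nM to 70000 nM in this assay for now.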

Compound 3, half-maximal inhibitory concentration: 21000 nM
Beside the measured number, compound 3's estimate is 1.2-fold (0.08 log units) above it, and the stated range covers the measured number.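

No step can be read between compound 2 and compound 3, since compound 2 has no number in this assay. As far as these compounds go, what putting 4-bromophenyl in place of 3-nitrophenyl does to this read-out stays open, and no supporting evidence bears on it.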